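The source may hold more compounds than are shown below. What is called first, only, known or untested is meant among the compounds shown, and "the series" means these compounds.

Measured so far: compound 1 `COc1ccc(CCCN2CCC(CO)CC2)cc1` with > 20000 nM; compound 2 `COc1ccc(CCCN2CCC(COC(c3ccc(Br)cc3)c3ccc(Br)cc3)CC2)cc1` with 3200 nM; compound 3 `CN1CCC(COC(c2ccccc2)c2ccccc2)CC1` with > 20000 nM.

In a functional assay on cells (T-cell line, Homo sapiens) for inhibition (on this read-out lower numbers stand for stronger inhibition and higher numbers for weaker inhibition), compound 3 gives only a limit, > 20000 nM, not a number. Compound 1 likewise sits at a limit, > 20000 nM. For the measured compounds named here, compound 3 thus stands at the limit of > 20000 nM in this assay, at which 2 of the 3 values shown sit, the weak end of what has been measured, while compound 2 is the only compound with a numerical value, 3200 nM. Compound 4 `CCCCCCCCCCN1CCC(COC(c2ccccc2)c2ccccc2)CC1` differs from compound 3 by nonyl in place of hydrogen on a saturated chain carbon bound to an amine nitrogen in a ring. Going by the values given here, no measured step covers this change. Given that compound 2, the one compound carrying a large substituent on the ring nitrogen, gives 3200 nM, compound 4 is expected to move to a measurable value, a step of an at least 3.3-fold lower number from compound 3 to compound 4 (0.52 log units; beyond the scatter) toward stronger inhibition, though the outcome remains uncertain. Compound 4 is estimated at 6000 nM, between 1500 nM and 20000 nM.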

Compound 4, half-maximal inhibitory concentration: 2600 nM
Compound 4: the middle estimate sits 2.3-fold (0.36 log units) above what was measured; the measured number falls inside the stated range.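

In this assay, the group carried on the amine nitrogen in a ring proves to matter: replacing methyl with decyl gives an at least 7.6-fold lower number from compound 3 to compound 4 (0.88 log units; beyond the scatter). A plain chain with no ring is enough for this step, which isolates the change at this one place. Compound 3 gives a limit and not a number, so the step has no fixed size: the limit of > 20000 nM in this assay, at which 2 of the 4 values shown sit.

From the compounds shown here alone, whether a shorter chain such as butyl, or a longer chain such as dodecyl, would serve as well remains open. So does the effect of a carboxylic acid on the decyl chain.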